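The source may report more compounds than this note shows. Statements on the series, on what has been measured and on what is new or still open speak of the compounds shown alone.

Compound 1 `O=C(CSc1nccn1-c1ccc(Cl)cc1)Nc1ccccc1[N+](=O)[O-]`: in an ADME assay on MT4 cells (Homo sapiens) for cytotoxicity, read by MTT assay (a higher number here means that more compound is tolerated, a lower number that less compound is tolerated), compound 1 gives > 321000 nM, which is a limit of the assay and not a number.
Compound 2 `COc1ccc(-n2ccnc2SCC(=O)Nc2ccc(C)cc2Br)cc1`: in this assay compound 2 gives 25800 nM.

Going by the values given here, compound 2 is thus the only compound here with a measured number in this assay; the other value shown is the limit (the limit of > 321000 nM in this assay, at which 1 of the 2 values shown sits). Compound 3 `COc1ccc(-n2ccnc2SCC(=O)Nc2ccccc2[N+](=O)[O-])cc1` is not yet measured. It differs from compound 2 by 2-nitrophenyl in place of 2-bromo-4-methylphenyl on an amide-type nitrogen, so that compound 3 carries the same 2-nitrophenyl on the amide-type nitrogen as compound 1, while keeping the rest of compound 2. Among the compounds with values here, with no step between measured compounds at hand, the direction of the change can only be guessed from compound 1 sitting at the limit of > 321000 nM in this assay, at which 1 of the 2 values shown sits. The step from compound 2 to compound 3 is therefore expected to be upward, a 5.8-fold higher number from compound 2 to compound 3 (0.76 log units; beyond the scatter), toward more compound tolerated. For compound 3 the estimate in this assay is 150000 nM, with a range from 40000 nM to 400000 nM.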

Compound 3, half-maximal cytotoxic concentration: 161000 nM
Estimate against measurement, compound 3: 1.1-fold (0.03 log units) below, within the range that was stated.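

In this assay, the group on the amide-type nitrogen proves to matter with the rest of the molecule held constant: 2-nitrophenyl in place of 2-bromo-4-methylphenyl gives a 6.2-fold higher number from compound 2 to compound 3 (0.80 log units; beyond the scatter), toward more compound tolerated. Methoxy in place of chloro on an aromatic carbon gives an at least 1.9-fold lower number from compound 1 to compound 3 (0.29 log units; that floor lies within the scatter), so this pair shows no clear effect of that change, as the floor of the step lies within the scatter. Compound 1 stands at a limit of the assay and not at a number, which leaves the true size of that step open: the limit of > 321000 nM in this assay, at which 1 of the 3 values shown sits.

The compounds shown leave open whether the higher number goes with the nitro group or with the loss of bromo and methyl, which change together in one step. They also do not show how an amine or a carboxylic acid in place of the nitro group would read.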